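Replacing a Ring Amide Substituent with a Butylamino Group

The compounds below may be only part of what the source reports. "The series", "measured", "known", "first", "only" and "open" are said of these compounds alone.

Within the data shown here, compound 2 `CN1CCN(C(=O)c2c(NC(=O)NS(=O)(=O)c3ccccc3)sc3c2CCCCC3)CC1` was tested in a functional assay on cells (Cancer cell lines, Homo sapiens) for inhibition, with a stated time of 48 h (a higher number here means a weaker inhibitor of growth, a lower number a stronger inhibitor of growth), where it gives 42300 nM, the higher of the two numbers measured so far, though that gap is within the scatter. Among the measured compounds shown here, compound 1 `O=C(Nc1sc2c(c1C(=O)NNc1ccccc1)CCCCC2)NS(=O)(=O)c1ccccc1` gives 26300 nM in this assay, and the single step between them, a 1.6-fold higher number from compound 1 to compound 2 (0.21 log units; within the scatter), alters the same carbonyl carbon that changes next. Compound 3 `CCCCNC(=O)c1c(NC(=O)NS(=O)(=O)c2ccccc2)sc2c1CCCCC2` differs from compound 2 by butylamino in place of 4-methylpiperazin-1-yl on a carbonyl carbon. Because a 1.6-fold higher number from compound 1 to compound 2 (0.21 log units; within the scatter) stayed within the scatter, no change beyond the scatter is expected here. Compound 3 is therefore estimated at 35000 nM, ranging from 12000 nM to 100000 nM, which amounts to an expected 1.2-fold lower number from compound 2 to compound 3 (0.08 log units; within the scatter).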

Compound 3, concentration for 50% growth inhibition: 72300 nM
The estimate for compound 3 lay 2.1-fold (0.32 log units) below the measured number; low and high end bracket the measured number.
By their numbers in this assay, from the lowest: compounds 1, 2 and 3 (each within the scatter of the next, the first and the last beyond it).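

On this carbonyl carbon, butylamino, which has no ring, and 4-methylpiperazin-1-yl remain within the scatter of each other (a 1.7-fold higher number from compound 2 to compound 3 (0.23 log units; within the scatter)). Butyl in place of anilino on an amide-type nitrogen gives the first step beyond the scatter in this series (a 2.7-fold higher number from compound 1 to compound 3 (0.44 log units; beyond the scatter)), a modest weakening of growth inhibition in this assay. Among these compounds, the group at this position can therefore shift the number, although only this one pair shows it. Going by these compounds, whether a longer chain or a carboxylic acid on the butyl chain would shift it further remains open. No measured evidence accounts for these differences.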